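The compounds below may be only part of what the source reports. "The series", "measured", "known", "first", "only" and "open" are said of these compounds alone.

Compound 2 `COc1ccc(-n2nc(C(=O)Nc3ccccc3OC)nc2-c2cc(OC)c(OC)c(OC)c2)cc1` gives 10% in a functional assay on the whole organism for inhibition, with Rattus norvegicus as the target, read by paw edema, with stated times of 30 min and 5 h, at a dose of 0.28 mmol/kg by the oral route (on this read-out higher numbers stand for more inhibition at the one dose given (going by the name of the read-out) and lower numbers for less inhibition), the lowest of the two numbers measured. Compound 1 `CCNC(=O)c1nc(-c2cc(OC)c(OC)c(OC)c2)n(-c2ccc(OC)cc2)n1`, with ethyl on the amide-type nitrogen instead, gives 52%, and the step of a number 42 percentage points lower from compound 1 to compound 2 (beyond the scatter) was large. Compound 3 `COc1ccc(-n2nc(C(=O)Nc3ccccc3C)nc2-c2cc(OC)c(OC)c(OC)c2)cc1` differs from compound 2 in one place: methyl in place of methoxy on an aromatic carbon. For the measured compounds named here, no measured step puts methyl in place of methoxy on an aromatic carbon, so the only step known bears on the amide side chain rather than on this change. Compound 3 is therefore expected to stay close to compound 2, with a step of a number 2 percentage points higher from compound 2 to compound 3 (within the scatter) within the scatter. Compound 3 is estimated at 12%, between 0% and 30%.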

Compound 3, a percentage reported as inhibition, in the whole organism at one dose (the size of the read-out at that dose, not a potency): 47%
Beside the measured number, compound 3's estimate is 35 percentage points below it; the measured number lies above the stated range.
By their numbers in this assay, from the lowest: compound 2; then compounds 3 and 1 (each within the scatter of the next).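

Methyl in place of methoxy, on an aromatic carbon ortho to a large group, changes the result sharply (a number 37 percentage points higher from compound 2 to compound 3 (beyond the scatter)). A phenyl ring on the amide nitrogen therefore does not by itself bring the low number of compound 2, since 2-methylphenyl in place of ethyl leaves the result within the scatter (a number 5 percentage points lower from compound 1 to compound 3 (within the scatter)). No measurement here explains why methoxy and methyl differ so much.

Still open, from the compounds shown here alone, is whether methoxy is unusual at this place or methyl is: a chlorine atom, an amine or a longer chain there would help to tell.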